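The source may report more compounds than this note shows. Statements on the series, on what has been measured and on what is new or still open speak of the compounds shown alone.

Measured compounds in an ADME assay on MCF-10A cells (Homo sapiens) for antiproliferative activity, read by sulforhodamine B assay, with a stated time of 48 h; on this read-out higher numbers stand for weaker inhibition and lower numbers for stronger inhibition:
Compound 1, `CC1(C)[C@@H]2CC3=NCC(=O)O[C@@]3(C)[C@H]1C2`, gives > 900000 nM, which is a limit of the assay and not a number.
Compound 2, `CC(C)(C)OC(=O)n1cnc(C[C@H]2N=C3C[C@H]4C[C@H](C4(C)C)[C@@]3(C)OC2=O)c1`, gives > 1300000 nM, likewise a limit.
Compound 3, `CC(C)(C)OC(=O)NCCC[C@@H]1N=C2C[C@@H]3C[C@@H](C3(C)C)[C@]2(C)OC1=O`, gives > 1200000 nM, likewise a limit.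

Compound 1 stands at the limit of > 900000 nM in this assay, at which 1 of the 3 values shown sits. Compound 3 sits at the limit of > 1200000 nM in this assay, at which 1 of the 3 values shown sits. Compound 2 sits at the limit of > 1300000 nM in this assay, at which 1 of the 3 values shown sits. Among the measured compounds shown here, none of the three measured compounds gives a number, so no measured step can be drawn between them and no direction can be read from them.

Compound 4, `CC1(C)[C@H]2CC3=NCC(=O)O[C@]3(C)[C@@H]1C2`, has not yet been measured in this assay. It differs from compound 1 as follows: the two compounds have the same atoms and bonds and differ only in configuration as drawn: 3 of 3 stereo elements differ (all stereocentres are inverted: mirror images); a stereocentre at a saturated ring carbon is drawn S in compound 1 and R in compound 4; a stereocentre at a saturated ring carbon is drawn S in compound 1 and R in compound 4; a stereocentre at a saturated ring carbon is drawn S in compound 1 and R in compound 4. With only limits among the measured compounds, the step that is expected, a step that the limit leaves unreadable from compound 1 to compound 4, is none beyond the scatter. Compound 4 is therefore estimated to give about 1000000 nM in this assay, within a range of 400000 nM to 3000000 nM, and it is expected most likely to be reported only as a limit once more.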

Compound 4, half-maximal inhibitory concentration: > 2000000 nM
Compound 4 ended at the assay's limit (the forecaster's own chance of this, stated with the estimate: 85%); at least 2.0-fold (0.30 log units) between middle value and limit.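

In this assay, compound 1 and compound 4 are both reported only as limits of the assay, so no step can be read between these two mirror images. The compounds shown leave open whether configuration changes this read-out at all, since none of them gives a number.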